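Replacing the carbamate cap with a pyridine ring

The source may hold more compounds than are shown below. What is called first, only, known or untested is meant among the compounds shown, and "the series" means these compounds.

Compound 1 `O=C(C1CC1)N1CCc2nc(C3(C(=O)Nc4ccc(F)cc4)CCC3)ccc21`: 8 nM
Compound 2 `O=C(c1cccc(Cl)c1)N1CCc2nc(C3(C(=O)Nc4ccc(F)cc4)CCC3)ccc21`: 3 nM
Compound 3 `O=C(OC1CC1)N1CCc2nc(C3(C(=O)Nc4ccc(F)cc4)CCC3)ccc21`: 2.7 nM

Three compounds sharing one core were tested in an assay on HeLa cells for inhibition of Indoleamine 2,3-dioxygenase 1 (Homo sapiens); a higher number here means a weaker inhibitor, a lower number a stronger inhibitor. Compound 3 gives the lowest number of the three, though its gap to compound 2 lies within the scatter; only the gap to compound 1 is clear, a step shown by a 3.0-fold lower number from compound 1 to compound 3 (0.47 log units; beyond the scatter) and, for compound 2, by a 2.7-fold lower number from compound 1 to compound 2 (0.43 log units; beyond the scatter). Compound 4 `O=C(Nc1ccc(F)cc1)C1(c2ccc3c(n2)CCN3c2ccccn2)CCC1` differs from compound 3 by pyridin-2-yl in place of cyclopropyloxycarbonyl on a nitrogen on an aromatic ring in a ring. Among the compounds with values here, every measured step changed only the group on a carbonyl carbon while keeping the carbonyl; none removed it or put an aromatic ring straight onto the nitrogen, so no measured step bears directly on this change. The three measured numbers lie close together, so compound 4 is expected to land near them, with a wide range, estimated at 10 nM (2 nM to 50 nM), a step of a 3.7-fold higher number from compound 3 to compound 4 (0.57 log units; beyond the scatter).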

Compound 4, half-maximal inhibitory concentration: 10.9 nM
The estimate for compound 4 lay 1.1-fold (0.04 log units) below the measured number, and the stated range covers the measured number.
By their numbers in this assay, from the lowest: compounds 3 and 2 (each within the scatter of the next); then compounds 1 and 4 (each within the scatter of the next).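

In this assay, the nitrogen of the shared core does not need a carbonyl: an aromatic ring placed directly on it still gives a strong inhibitor. Pyridin-2-yl loses ground against cyclopropyloxycarbonyl (a 4.0-fold higher number from compound 3 to compound 4 (0.61 log units; beyond the scatter)) and against (3-chlorophenyl)carbonyl (a 3.6-fold higher number from compound 2 to compound 4 (0.56 log units; beyond the scatter)), but it cannot be told apart from cyclopropylcarbonyl (a 1.4-fold higher number from compound 1 to compound 4 (0.13 log units; within the scatter)). No measurement here explains these differences. From the compounds shown here alone, what a phenyl ring would give on this nitrogen remains open, so the contribution of the pyridine nitrogen is unknown.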